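The source may report more compounds than this note shows. Statements on the series, on what has been measured and on what is new or still open speak of the compounds shown alone.

Compound 2, `COC(C)(C)/C=C/C/C(C)=C/Cc1c(O)ccc2c1O[C@H](c1ccc(O)cc1)CC2=O`, in a functional assay on HT-29 cells (Homo sapiens) for cytotoxicity, read by MTT assay (a higher number here means a weaker inhibitor, a lower number a stronger inhibitor), gives > 10000 nM, which is a limit of the assay rather than a number. Compound 1, `C/C(=C\Cc1c(O)ccc2c1O[C@H](c1ccc(O)cc1)CC2=O)C/C=C/C(C)(C)O`, in this assay gives > 10000 nM, likewise a limit. Among the compounds with values here, the one measured step, a step that the two limits leave unreadable from compound 1 to compound 2, therefore cannot be read in size or direction, and the only evidence available is the limit of > 10000 nM in this assay, at which 2 of the 2 values shown sit. Compound 3, `C=C(C)C(O)CC/C(C)=C/Cc1c(O)ccc2c1O[C@H](c1ccc(O)cc1)CC2=O`, has not yet been measured in this assay. It differs from compound 2 by 2-hydroxy-3-methylbut-3-en-1-yl in place of 3-methoxy-3-methylbut-1-en-1-yl on a saturated chain carbon bound to a double-bonded chain carbon. Within the data shown here, no measured step covers a change of this kind, and the single step that exists gives no readable size, so there is no ground for expecting a shift beyond the scatter. Compound 3 is therefore expected to give 15000 nM, within a range from 5000 nM to 50000 nM. The step that the limit leaves unreadable from compound 2 to compound 3 is expected to lie within the usual scatter.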

Compound 3, half-maximal inhibitory concentration: > 10000 nM
Compound 3 was reported as a limit (the forecaster's own chance of this, stated with the estimate: 80%); the middle value is on the limit's open side.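

Compound 3, like compound 1 and compound 2, is reported only as a limit, so no step among these three compounds can be read in size or direction: the limit of > 10000 nM in this assay, at which 3 of the 3 values shown sit.

The compounds shown leave open whether changing this side chain alters activity in this assay at all, and what the actual value of each compound is.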